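A Dimethoxyphenyl Shift Between Two Limits

This account rests on a few compounds, and the source may have more. Where it says the series, first, only, none or still open, it means among the compounds named here.

Measured compounds:
Compound 1 `COc1ccc(/C=C/C(=O)/C=C/c2cc3ccccc3nc2Oc2ccccc2)c(OC)c1`: > 10000 nM
Compound 2 `COc1ccc(/C=C/C(=O)/C=C/c2cc3ccccc3nc2Oc2ccc(Br)cc2)c(OC)c1`: > 10000 nM

Both entries come from a functional assay on DU-145 cells (Homo sapiens) for cytotoxicity, read by MTT assay, with a stated time of 48 h (on this read-out higher numbers stand for weaker inhibition and lower numbers for stronger inhibition), and neither is a number. Compound 2 stands at > 10000 nM, which is a limit of the assay. The whole record so far is the limit of > 10000 nM in this assay, at which 2 of the 2 values shown sit, so compound 2 cannot be ranked against compound 1.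

Compound 3 `COc1ccc(/C=C/C(=O)/C=C/c2cc3ccccc3nc2Oc2ccc(Br)cc2)cc1OC` has the same atoms as compound 2, joined differently: 3,4-dimethoxyphenyl in place of 2,4-dimethoxyphenyl on a double-bonded chain carbon bound to a double-bonded chain carbon. It carries 3,4-dimethoxyphenyl in place of 2,4-dimethoxyphenyl on a double-bonded chain carbon bound to a double-bonded chain carbon.

Among the compounds with values here, only one measured step exists, a step that the two limits leave unreadable from compound 1 to compound 2. It is a different change, bromo in place of hydrogen on an aromatic carbon, and it offers no size to carry over. Within the data shown here, no measured step tests the shift of a methoxy group. In this assay, the expectation is therefore no readable step, with compound 3 most likely reported as a limit again. Any number that does appear would be expected to show somewhat stronger inhibition. The expected change is a number no higher from compound 2 to compound 3 (the limit leaves the size open). Compound 3 is estimated at 10000 nM, with an expected range of 3000 nM to 30000 nM.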

Compound 3, half-maximal inhibitory concentration: > 10000 nM
Compound 3 was reported as a limit (the forecaster's own chance of this, stated with the estimate: 65%); the middle value sits exactly at the limit.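

In this assay compound 3 gives > 10000 nM as a limit of the assay and not a number. No step can be read between compound 2 and compound 3, and the record remains flat: the limit of > 10000 nM in this assay, at which 3 of the 3 values shown sit. The compounds shown leave open whether 3,4-dimethoxyphenyl in place of 2,4-dimethoxyphenyl changes inhibition at all, and how strongly any of them inhibits.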